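This account rests on a few compounds, and the source may have more. Where it says the series, first, only, none or still open, it means among the compounds named here.

Measured in an ADME assay on liver (Homo sapiens) for metabolic stability, read by LC-MS, using microsomes and NADPH; on this read-out lower numbers stand for a less stable compound and higher numbers for a more stable compound:
- compound 1 `Cc1cc(CN(CC2CC2)[C@@H](CC(=O)O)c2ccc(Cl)cc2)ccc1OCCN1C(=O)CCC1=O`: 90%
- compound 2 `CCCN(Cc1ccc(OCCn2c(=O)ccn(C)c2=O)c(C)c1)C(CC(=O)O)c1ccc(Cl)cc1`: 30%
- compound 3 `CCCN(Cc1ccc(OCCn2c(=O)ccn(C)c2=O)c(OC)c1)C(CC(=O)O)c1ccc(Cl)cc1`: 61%

Among these three, compound 3 holds the middle place at 61%. Compound 1 reads 90% and compound 2 reads 30%, and both gaps to compound 3 lie beyond the scatter.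

Compound 4 `CCCCN(Cc1ccc(OCCn2c(=O)ccn(C)c2=O)c(OC)c1)C(CC(=O)O)c1ccc(Cl)cc1` differs from compound 3 only in the chain on the amine, where propyl becomes butyl: methyl in place of hydrogen on a saturated chain carbon, three bonds along the chain from an amine nitrogen. In words, this is methyl in place of hydrogen on a saturated chain carbon, three bonds along the chain from an amine nitrogen.

For the measured compounds named here, only one measured step links two compounds that differ in one place: a number 31 percentage points higher from compound 2 to compound 3 (beyond the scatter). That step is large, but it is methoxy in place of methyl on an aromatic carbon, elsewhere in the molecule, so it does not speak directly to the chain. Going by the values given here, no measured step covers a change in this chain. A modest fall is therefore expected, possibly no larger than the scatter, starting from compound 3 at 61%. The estimated change is a number 9 percentage points lower from compound 3 to compound 4 (within the scatter). The range stays wide, since one change alone gave a number 31 percentage points higher from compound 2 to compound 3 (beyond the scatter). For compound 4 the expected value is 52%, with an estimated range of 32% to 68%.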

Compound 4, percent of the compound remaining: 38%
The estimate for compound 4 lay 14 percentage points above the measured number, and the stated range covers the measured number.
By their numbers in this assay, from the lowest: compounds 2 and 4 (each within the scatter of the next); then compound 3; then compound 1.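

In this assay, the amine chain proves to be a position that responds on its own: lengthening propyl to butyl, methyl in place of hydrogen on a saturated chain carbon, three bonds along the chain from an amine nitrogen, gives a number 23 percentage points lower from compound 3 to compound 4 (beyond the scatter) with the rest of the molecule unchanged. For the compounds shown here, until now the only single-place comparison concerned an aromatic carbon, so the earlier compounds gave no reading of this chain, and this step shows that a single added carbon far out on it is enough to move the number past the usual scatter of the measurement. Nothing available here bears on why the number falls with this change.

The compounds shown leave open whether the trend runs on along the chain, since an ethyl or a pentyl group on the amine, or a branched chain such as isobutyl, would show whether the fall continues, levels off or reverses. They also leave open whether the same lengthening would cost as much with methyl in place of methoxy on the aromatic carbon, or with a chain ending in a hydroxyl group.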